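Adding a Nitro Group to a Rearranged Core

The compounds below may be only part of what the source reports. "The series", "measured", "known", "first", "only" and "open" are said of these compounds alone.

Compound 1 `COc1ccc(-c2sc(C(=O)O)cc2-c2cc(OC)c(OC)c(OC)c2)cc1` and compound 3 `COc1ccc(-c2cc(C(=O)O)sc2-c2cc(OC)c(OC)c(OC)c2)cc1` are built from the same atoms joined differently; the difference between the two cores is not broken down here. In a functional assay on HT-1080 cells (Homo sapiens) for antiproliferative activity, read by MTT assay, with a stated time of 72 h (on this read-out higher numbers stand for weaker inhibition and lower numbers for stronger inhibition), compound 1 gives 6770 nM, and in the same assay compound 3 gives 5810 nM, two numbers that lie within the scatter of each other. Compound 2 `COc1ccc(-c2sc(C(=O)O)cc2-c2cc(OC)c(OC)c(OC)c2)cc1[N+](=O)[O-]` differs from compound 1 by one change, (nitro in place of hydrogen on an aromatic carbon). In this assay compound 2 gives 37200 nM, which means the change produced a 5.5-fold higher number from compound 1 to compound 2 (0.74 log units; beyond the scatter). Compound 4 `COc1ccc(-c2cc(C(=O)O)sc2-c2cc(OC)c(OC)c(OC)c2)cc1[N+](=O)[O-]`, not yet measured, carries the same change on the core of compound 3, (nitro in place of hydrogen on an aromatic carbon), and the surroundings of the new group read the same in both cases. Compound 4 is expected to move the way compound 2 did, because the identical change gave a 5.5-fold higher number from compound 1 to compound 2 (0.74 log units; beyond the scatter) and the two cores behave alike without the nitro group, so the expected step is a 5.2-fold higher number from compound 3 to compound 4 (0.71 log units; beyond the scatter). Compound 4 is therefore estimated at 30000 nM, with a likely range from 12000 nM to 80000 nM.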

Compound 4, half-maximal inhibitory concentration: 38100 nM
Beside the measured number, compound 4's estimate is 1.3-fold (0.10 log units) below it; the range from low to high includes it.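

In this assay, putting a nitro group in place of hydrogen on the core of compound 3 gave a 6.6-fold higher number from compound 3 to compound 4 (0.82 log units; beyond the scatter), so the loss of inhibition seen on the core of compound 1 appeared again. The two steps match in size, which means that this change carried over from one core to the other: the same change on two cores in this assay, a 5.5-fold higher number (0.74 log units; beyond the scatter) from compound 1 to compound 2 and a 6.6-fold higher number (0.82 log units; beyond the scatter) from compound 3 to compound 4, 1.2-fold (0.08 log units) apart, within the scatter of two such steps. This agreement rests on just two pairs of compounds in a single cell assay, and it shows neither why the nitro group weakens inhibition nor that the same step would appear on any further core.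

The compounds shown carry only hydrogen or nitro at this position on the ring, so it stays open whether an amine, a fluorine or a nitrile there would give a similar step. All four compounds also keep the carboxylic acid, which leaves open whether the nitro step would look the same with a methyl ester or an amide in its place.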